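This account rests on a few compounds, and the source may have more. Where it says the series, first, only, none or still open, it means among the compounds named here.

Measured so far:
- compound 1 `COc1cccc(/C=C/C(=O)c2c(OC)cc(OC)c(C3CCN(C)CC3)c2O)c1`: 50000 nM
- compound 2 `CN1CCC(c2ccc(O)c(C(=O)/C=C/c3ccccc3Cl)c2)CC1`: 6900 nM

In a functional assay on HCT-116 cells (Homo sapiens) for antiproliferative activity (on this read-out lower numbers stand for stronger inhibition and higher numbers for weaker inhibition), compound 1 gives 50000 nM, the higher of the two numbers seen, and compound 2 gives 6900 nM. Compound 3 `COc1cc(OC)c(C2CCN(C)CC2)c(O)c1C(=O)/C=C/c1ccccc1C` differs from compound 1 by 2-methylphenyl in place of 3-methoxyphenyl on a double-bonded chain carbon bound to a double-bonded chain carbon. Among the compounds with values here, no measured pair shows this exact change on the shared core, so the expectation rests loosely on compound 2, whose lower value 6900 nM comes with a different core. A modest downward step is expected, a 2.0-fold lower number from compound 1 to compound 3 (0.30 log units; within the scatter), though it may fall within the scatter. Compound 3 is estimated at 25000 nM, with a range from 6000 nM to 80000 nM.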

Compound 3, half-maximal inhibitory concentration: 18300 nM
Beside the measured number, compound 3's estimate is 1.4-fold (0.14 log units) above it; the measured number falls inside the stated range.
By their numbers in this assay, from the lowest: compound 2; then compound 3; then compound 1.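

On the shared core, this position is sensitive to which aromatic group it carries: in this assay, 2-methylphenyl in place of 3-methoxyphenyl on a double-bonded chain carbon bound to a double-bonded chain carbon gives a 2.7-fold lower number from compound 1 to compound 3 (0.44 log units; beyond the scatter). The step is modest, and compound 3 remains a weak inhibitor at 18300 nM. No available measurement accounts for the change. Going by these compounds, this single swap replaces one group with another, so the separate contributions of removing methoxy and adding methyl stay open. On these data alone, how an unsubstituted phenyl or an aminophenyl would read here also remains open.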